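The source may hold more compounds than are shown below. What is called first, only, known or untested is meant among the compounds shown, and "the series" means these compounds.

Of the compounds shown here, three share one core and have been tested in an assay on isolated protein for inhibition of Dopamine beta-hydroxylase (Bos taurus); on this read-out lower numbers stand for stronger inhibition and higher numbers for weaker inhibition. Compound 1 `Sc1nccn1Cc1cccs1` gives 4800 nM. Compound 2 `Sc1nccn1Cc1ccsc1` gives 5300 nM. Compound 3 `Cc1ccc(Cn2ccnc2S)s1` gives 6000 nM. In this assay, compound 3 sits alongside the other two, its number lying within the scatter of both compound 1 and compound 2, so no difference between any of these three can be claimed. For the measured compounds named here, the one single-point step available, from compound 1 to compound 3, was a 1.3-fold higher number from compound 1 to compound 3 (0.10 log units; within the scatter), meaning the added methyl did not shift the read-out beyond the scatter.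

Compound 4 `Sc1nccn1Cc1ccc(Cl)s1` has not yet been measured. It differs from compound 3 in one place: chloro in place of methyl on an aromatic carbon. Going by the values given here, no measured step swaps methyl for chloro at this position, so the only guide is the step from compound 1 to compound 3, which was flat. In this assay, compound 4 is therefore expected to show no step beyond the scatter, an estimated change of a 1.1-fold lower number from compound 3 to compound 4 (0.04 log units; within the scatter). The estimate for compound 4 is 5500 nM, in a range from 2000 nM to 15000 nM.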

Compound 4, half-maximal inhibitory concentration: 1000 nM
Estimate against measurement, compound 4: 5.5-fold (0.74 log units) above, and the stated range ends above it.
By their numbers in this assay, from the lowest: compound 4; then compounds 1, 2 and 3 (each within the scatter of the next).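

In this assay, this position on the shared core proves able to change the read-out, although the swap of hydrogen for methyl had shown no shift beyond the scatter. Chloro in place of methyl gives a 6.0-fold lower number from compound 3 to compound 4 (0.78 log units; beyond the scatter), and chloro in place of hydrogen gives a 4.8-fold lower number from compound 1 to compound 4 (0.68 log units; beyond the scatter), so the result depends on which group enters, even though methyl and chloro each count as one heavy atom. Nothing available here explains why chloro and methyl differ.

From the compounds shown here alone, whether bromo, fluoro, methoxy or a nitrile at this position would match chloro remains open. Also open, going by these compounds, is whether chloro on a different carbon of the same ring would give a step of similar size.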